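Amide series: stereo-undefined analogue of compound 3

The source may report more compounds than this note shows. Statements on the series, on what has been measured and on what is new or still open speak of the compounds shown alone.

Measured compounds in an assay on Sf9 cells for inhibition of Amine oxidase [flavin-containing] A (Homo sapiens), with stated times of 15 min and 60 min; on this read-out higher numbers stand for weaker inhibition and lower numbers for stronger inhibition:
compound 1 `Cc1cc(OCc2cccc(F)c2)ccc1CN[C@@H](C)C(N)=O` gives > 10000 nM, which is a limit of the assay and not a number.
compound 2 `C#CCN(Cc1ccc(OCc2cccc(F)c2)cc1F)[C@@H](C)C(N)=O` gives 8710 nM.
compound 3 `NC(=O)[C@@H]1CCN1Cc1ccc(OCc2cccc(F)c2)cc1` gives 26800 nM.

Compound 3 holds the highest of the two numbers; its nearest neighbour is compound 2, whose value lies lower by a gap beyond the scatter. Compound 1 contributes only a limit (the limit of > 10000 nM in this assay, at which 1 of the 3 values shown sits). Compound 4 `NC(=O)C1CCN1Cc1ccc(OCc2cccc(F)c2)cc1` has the same atoms and bonds as compound 3; (the two compounds have the same atoms and bonds; at least one stereo element is drawn with a configuration in one of them and without one in the other: 1 of 1 stereo elements differ; a stereocentre at a saturated ring carbon is drawn S in compound 3 and without a configuration in compound 4). Among the measured compounds shown here, no measured step of this kind exists, so only a small change is expected in this assay: the estimated step from compound 3 to compound 4 is a 1.2-fold higher number from compound 3 to compound 4 (0.08 log units; within the scatter), no further than the scatter, in the weaker direction if at all. Compound 4 is estimated at 32000 nM, with a likely range from 13000 nM to 80000 nM.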

Compound 4, half-maximal inhibitory concentration: 18000 nM
Compound 4: middle estimate off by 1.8-fold (0.25 log units), on the high side; the measured number falls inside the stated range.
By their numbers in this assay, from the lowest: compound 2; then compounds 4 and 3 (each within the scatter of the next).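

In this assay, among the compounds shown here, the stereocentre at the saturated ring carbon can now be read for the first time, with a step of a 1.5-fold lower number from compound 3 to compound 4 (0.17 log units; within the scatter). Compound 3 and compound 4 therefore lie within the scatter of each other, so the drawn S configuration gives no visible separation on this read-out. The pair cannot assign a value to either configuration on its own, because of this: the fact that one of compounds 3 and 4 is drawn with a defined configuration and the other without, at the place where they differ

On these data alone, the value of the opposite configuration, drawn alone, remains open. So does whether a carboxylic acid in place of the amide would shift the number at all.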